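Quinoline sulfone series: fluoro to methoxy on the fused ring

This account rests on a few compounds, and the source may have more. Where it says the series, first, only, none or still open, it means among the compounds named here.

Measured compounds:
- Compound 1 `CC1CCN(c2c(S(=O)(=O)c3cc(Cl)cc(Cl)c3)cnc3ccc(F)cc23)CC1`: 69%
- Compound 2 `CC1CCN(c2c(S(=O)(=O)c3ccccc3)cnc3ccc(F)cc23)CC1`: 40%

For the measured compounds named here, in an assay on isolated protein for displacement of a labelled ligand from metabotropic glutamate receptor 5 (Homo sapiens), with a stated time of 60 min, tested at 1 uM (a lower number here means less inhibition, a higher number more inhibition at the concentration tested (going by the name of the read-out)), compound 1 gives 69%, the highest of the two numbers in hand; compound 2 gives 40%, and the only step within the measured set, a number 29 percentage points lower from compound 1 to compound 2 (beyond the scatter), sets phenyl on the sulfonyl sulfur against 3,5-dichlorophenyl.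

Compound 3 `COc1ccc2ncc(S(=O)(=O)c3cc(Cl)cc(Cl)c3)c(N3CCC(C)CC3)c2c1` keeps the 3,5-dichlorophenyl sulfone and the piperidine of compound 1; the change is methoxy in place of fluoro on an aromatic carbon, the fluoro leaving and a methoxy entering on the six-membered aromatic ring of carbon only that belongs to the fused two-ring system. Going by the values given here, no measured step touches this ring; the step from compound 1 to compound 2 concerns the sulfonyl aryl alone and cannot be carried over. Nothing in hand therefore argues for a shift beyond the scatter in either direction in this assay.

Compound 3 is expected to stay close to compound 1, the estimated step being a number 4 percentage points lower from compound 1 to compound 3 (within the scatter). The estimate for compound 3 in this assay is 65%, with a range from 45% to 85%.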

Compound 3, a percentage reported as inhibition, at one concentration (the size of the read-out at that concentration, not a potency): 87%
The estimate for compound 3 lay 22 percentage points below the measured number; the measured number lies above the stated range.
By their numbers in this assay, from the lowest: compound 2; then compound 1; then compound 3.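

In this assay the six-membered aromatic ring of carbon only proves to be a place that responds to a single change: with the 3,5-dichlorophenyl sulfone and the methylpiperidine held fixed, methoxy in place of fluoro gives a number 18 percentage points higher from compound 1 to compound 3 (beyond the scatter) in this series. Until this result, the only change shown to move the number was on the sulfonyl aryl, with a number 29 percentage points lower from compound 1 to compound 2 (beyond the scatter) on going to phenyl, so the series now has a second place where one substitution carries a step beyond the scatter, and here the number rises rather than falls. No measurement in hand bears on why methoxy gives the higher number at this carbon.

With only fluoro and methoxy shown at this carbon, it remains open whether the rise is specific to methoxy, and an ethoxy group, a hydroxyl or an amine at the same place would help to settle that. Also open, as far as these compounds go, is whether the same rise would appear with phenyl on the sulfonyl sulfur, as in compound 2, or belongs only to the 3,5-dichlorophenyl sulfone.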